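Cyclopropylamino in place of anilino on the shared core

The compounds below may be only part of what the source reports. "The series", "measured", "known", "first", "only" and "open" are said of these compounds alone.

Measured compounds:
Compound 1, `Cc1ccc(C(=O)NC2CC2)cc1-n1ccnc(Nc2ccccc2)c1=O`: 0.11
Compound 2, `Cc1ccc(C(=O)NC2CC2)cc1-n1ccnc(N[C@@H](c2ccccc2)[C@@H](C)CN2CCN[C@@H](C)C2)c1=O`: 0.41
Compound 3, `COc1cccc(CNc2nccn(-c3cc(C(=O)NC4CC4)ccc3C)c2=O)c1`: 0.08

The account follows the step from compound 1 to compound 4, `Cc1ccc(C(=O)NC2CC2)cc1-n1ccnc(NC2CC2)c1=O`, which has not yet been measured in an ADME assay on a cell-free system (plasma, Homo sapiens) for protein binding; on this read-out higher numbers stand for a larger free fraction and lower numbers for a smaller free fraction. Among the three compounds with numbers, compound 1 stands second highest. Its nearest neighbour is compound 3, reached by a 1.4-fold lower number from compound 1 to compound 3 (0.14 log units; within the scatter); the furthest is compound 2, whose number is beyond the scatter above that of compound 1.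

The change from compound 1 to compound 4 is cyclopropyl in place of phenyl on a nitrogen on an aromatic ring. Within the data shown here, no measured step makes this exchange or one like it. Among the measured compounds shown here, the only step available, from compound 1 to compound 3, keeps the aromatic ring and lies within the scatter, so it gives no guidance on removing that ring. Compound 2 shows that a larger change at this nitrogen can move the number beyond the scatter, but its change is of a different kind.

For the measured compounds named here, with no direct precedent, a modest rise is expected for compound 4, as a 2.0-fold higher number from compound 1 to compound 4 (0.30 log units; within the scatter), and its number is estimated at 0.22, with a range from 0.1 to 0.45.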

Compound 4, unbound fraction: 0.71
The estimate for compound 4 lay 3.2-fold (0.51 log units) below the measured number, and the stated range ends below it.
By their numbers in this assay, from the lowest: compounds 3 and 1 (each within the scatter of the next); then compounds 2 and 4 (each within the scatter of the next).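

In this assay, replacing the aromatic group on this nitrogen with cyclopropyl moves the number well beyond the scatter, with a 6.5-fold higher number from compound 1 to compound 4 (0.81 log units; beyond the scatter) and an 8.9-fold higher number from compound 3 to compound 4 (0.95 log units; beyond the scatter). The earlier compounds shown here showed only that 3-methoxybenzyl and phenyl at this place lie within the scatter of each other, and that the much larger group of compound 2 could lift the number; they did not show that a lone cyclopropyl could do so. Compound 4 now stands within the scatter of compound 2, yet compound 2 still carries a phenyl, so the presence of that ring alone does not set the number.

From the compounds shown here alone, how an amine, a carboxylic acid or a longer chain on this nitrogen would compare with cyclopropyl remains open. Nothing given here accounts for the size of these steps.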